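Hemolysis of a biaryl-thiophene amidine series: chloro for methoxy

The source may report more compounds than this note shows. Statements on the series, on what has been measured and on what is new or still open speak of the compounds shown alone.

For the measured compounds named here, compound 2 `COc1ccc(-c2ccc(-c3ccc(C(=N)N)s3)s2)cc1` is the only member of the series with a number in an ADME assay on cells (Erythrocyte, Homo sapiens) for activation, read by hemolysis, with a stated time of 30 min, tested at 0.625 mM; a lower number here means a weaker effect, a higher number a stronger effect of the compound at the concentration tested: compound 2 gives 4%. Going by the values given here, compound 1 `N=C(N)c1ccc(-c2ccc(-c3ccccc3)s2)s1` is the one further entry, recorded in this assay only as "non-toxic" (no number reported) without a number, so no step between measured compounds can be computed. Compound 3 `N=C(N)c1ccc(-c2ccc(-c3ccc(Cl)cc3)s2)s1` has not yet been measured in this assay. Relative to compound 2 it shows the change (chloro in place of methoxy on an aromatic carbon). Among the compounds with values here, with no measured step in this assay to lean on, the expectation rests on compound 2 alone, whose read-out of 4% is a small one, and on compound 1 being recorded as "non-toxic" (no number reported). The step of a number 2 percentage points higher from compound 2 to compound 3 (within the scatter) is expected to stay within the usual scatter, in no particular direction. Compound 3 is estimated to give 6%, with a range from 0% to 20%.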

Compound 3, a percentage reported as activity, at one concentration (the size of the read-out at that concentration, not a potency): "non-toxic" (no number reported)
Compound 3 has no reported number here; the estimate stays without a comparison.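

In this assay, for the compounds shown here, compound 3 is recorded as "non-toxic" (no number reported) and carries no number, so no step from compound 2 to compound 3 can be read. No supporting data bear on this result. The compounds shown leave open whether chloro and methoxy differ at all in this read-out.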